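Replacing a bromophenyl ketone with a phenylphenyl ketone

The source may report more compounds than this note shows. Statements on the series, on what has been measured and on what is new or still open speak of the compounds shown alone.

Three compounds share one core and differ only in the aromatic ring on the carbonyl carbon. Compound 1 `COc1cc(-c2nnc3n2NC(c2ccco2)C(C(=O)c2ccc(Br)cc2)S3)cc(OC)c1OC` reaches only the limit > 100000 nM in a functional assay on MCF7 cells (Homo sapiens) for cytotoxicity, read by MTT assay, with a stated time of 48 h; on this read-out higher numbers stand for weaker inhibition and lower numbers for stronger inhibition. Compound 2 `COc1cc(-c2nnc3n2NC(c2ccco2)C(C(=O)c2ccccc2)S3)cc(OC)c1OC` gives 39800 nM in this assay, and compound 3 `COc1cc(-c2nnc3n2NC(c2ccco2)C(C(=O)c2cccc(Br)c2)S3)cc(OC)c1OC` gives 91800 nM. Among the two plain numbers, compound 3 has the higher one, so it is the weaker of the two measured compounds. The measured steps are modest: a 2.3-fold higher number from compound 2 to compound 3 (0.36 log units; beyond the scatter), while an at least 2.5-fold lower number from compound 1 to compound 2 (0.40 log units; beyond the scatter). For compound 1 itself only a limit is known (the limit of > 100000 nM in this assay, at which 1 of the 3 values shown sits).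

Compound 4 `COc1cc(-c2nnc3n2NC(c2ccco2)C(C(=O)c2ccc(-c4ccccc4)cc2)S3)cc(OC)c1OC` carries 4-phenylphenyl in place of 3-bromophenyl on a carbonyl carbon. Among the compounds with values here, no measured step adds a second ring here; the steps that exist show that a bromo on this ring raised the number, and compound 1 with a bromo on the ring reached only the limit. A still larger group at the same place is therefore expected to keep the number high, and the step is expected to be a 1.3-fold higher number from compound 3 to compound 4 (0.12 log units; within the scatter). Compound 4 is estimated at 120000 nM, in a range from 40000 nM to 400000 nM, with a fair chance that only a limit is reported.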

Compound 4, half-maximal inhibitory concentration: > 100000 nM
Compound 4 gave a limit, no number (the forecaster's own chance of this, stated with the estimate: 50%); the middle value does not contradict the limit.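

Putting phenyl in place of hydrogen on the aromatic ring gives an at least 2.5-fold higher number from compound 2 to compound 4 (0.40 log units; beyond the scatter) in this assay, so a second ring here, like the bromo of compound 3, goes with weaker inhibition than the unsubstituted ring of compound 2. Replacing 3-bromophenyl with 4-phenylphenyl gives an at least 1.0-fold higher number from compound 3 to compound 4 (0.03 log units; that floor lies within the scatter), so these two compounds cannot be put in order. Compound 1 and compound 4 both sit at a limit, so the step between them cannot be read: the limit of > 100000 nM in this assay, at which 2 of the 4 values shown sit.

As far as these compounds go, only bromo and phenyl appear as added groups on this ring, so it remains open whether a methoxy group, an amine or a carboxylic acid there would lower the number below that of compound 2. From the compounds shown here alone, how far compound 4 lies past its limit also remains open.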